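The source may hold more compounds than are shown below. What is called first, only, known or untested is meant among the compounds shown, and "the series" means these compounds.

Compound 1 `COc1ccc(/C=C2\CN(Cc3cn(Cc4cccc(Cl)c4)nn3)C/C(=C\c3ccc(OC)cc3)C2=O)cc1`: 99000 nM
Compound 2 `COc1ccc(/C=C2\CN(Cc3cn(Cc4ccc(F)cc4)nn3)C/C(=C\c3ccc(OC)cc3)C2=O)cc1`: > 100000 nM
Compound 3 `O=C1/C(=C/c2ccccc2F)CN(Cc2cn(Cc3ccccc3Cl)nn2)C/C1=C\c1ccccc1F`: 10000 nM

All three values come from a functional assay on MCF7 cells (Homo sapiens) for cytotoxicity, read by MTT assay, with a stated time of 24 h; a lower number here means a stronger inhibitor, a higher number a weaker inhibitor. Compound 2 stands at the limit of > 100000 nM in this assay, at which 1 of the 3 values shown sits, and that is a limit, not a number. Compound 4 `COc1ccc(/C=C2\CN(Cc3cn(Cc4ccccc4F)nn3)C/C(=C\c3ccc(OC)cc3)C2=O)cc1` keeps the core of compound 2 and changes one group: 2-fluorophenyl in place of 4-fluorophenyl on a saturated chain carbon bound to an aromatic nitrogen. In words, it carries 2-fluorophenyl in place of 4-fluorophenyl on a saturated chain carbon bound to an aromatic nitrogen. Among the compounds with values here, the one measured step at this place, a number no lower from compound 1 to compound 2 (the limit leaves the size open), has no readable size. Compound 3 differs from the others in more than one place, so it offers no clean guide. With compound 1 at 99000 nM, the expected change is small and towards a lower number, an at least 1.2-fold lower number from compound 2 to compound 4 (0.09 log units; that floor lies within the scatter). For compound 4 the estimate is 80000 nM, with an expected range of 25000 nM to 150000 nM.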

Compound 4, half-maximal inhibitory concentration: >= 100000 nM
Compound 4 ended at the assay's limit (the forecaster's own chance of this, stated with the estimate: 45%); middle value at least 1.2-fold (0.09 log units) from the limit.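

Compound 4 gives a limit of the assay, not a number: the limit of >= 100000 nM in this assay, at which 1 of the 4 values shown sits. Compound 2 also gives a limit, not a number: the limit of > 100000 nM in this assay, at which 1 of the 4 values shown sits. In this assay, then, neither 4-fluorophenyl nor 2-fluorophenyl at this place on the shared core yields a measured number, and the step to compound 4 from compound 2 cannot be read. 2-Fluorophenyl in place of 3-chlorophenyl gives a number no lower from compound 1 to compound 4 (the limit leaves the size open) and no more than that.

Still open, as far as these compounds go, is whether an amine or a carboxylic acid on this phenyl ring would give a readable number with this core.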